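Aryl replacement on the saturated ring carbon: compound 4

A few compounds are considered here, and "the series" means these few. Any claim that something is new, unique, unknown or untested is made for them only; others in the source may bear on it.

Measured in a functional assay on MCF7 cells (Homo sapiens) for antiproliferative activity, read by MTT assay, with stated times of 24 h and 72 h; on this read-out lower numbers stand for stronger inhibition and higher numbers for weaker inhibition:
- compound 1, `COc1cc([C@@H]2[C@H](Oc3ccccc3)C(=O)N2c2cc(OC)c(OC)c(OC)c2)cc(OC)c1OC`: 29000 nM
- compound 2, `COc1cc(N2C(=O)[C@@H](Oc3ccccc3)[C@H]2c2ccc3ccccc3c2)cc(OC)c1OC`: 282000 nM
- compound 3, `COc1cc(N2C(=O)[C@@H](Oc3ccccc3)[C@H]2c2cccc([N+](=O)[O-])c2)cc(OC)c1OC`: 30000 nM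

Compound 1 gives the lowest number of the three; compound 3 lies within the scatter of it, a 1.0-fold higher number from compound 1 to compound 3 (0.01 log units; within the scatter), while compound 2 stands further off, a 9.7-fold higher number from compound 1 to compound 2 (0.99 log units; beyond the scatter). Compound 4, `COc1cc(N2C(=O)[C@@H](Oc3ccccc3)[C@H]2c2cc(O)c(OC)c([N+](=O)[O-])c2)cc(OC)c1OC`, has not yet been measured. Relative to compound 1 the change is a group of 12 heavy atoms (7 carbon, 1 nitrogen, 4 oxygen; one six-membered aromatic ring of carbon only) in place of a group of 12 heavy atoms (9 carbon, 3 oxygen; one six-membered aromatic ring of carbon only), on a saturated ring carbon. Within the data shown here, the only step that bears on it is that from compound 1 to compound 3, where a nitro-bearing ring in place of 3,4,5-trimethoxyphenyl left the number unchanged within the scatter. Among the measured compounds shown here, no measured step covers the added hydroxy and methoxy. For compound 4 no step beyond the scatter is therefore expected in this assay, a 1.2-fold lower number from compound 1 to compound 4 (0.06 log units; within the scatter), and the estimate is 25000 nM with a range of 8000 nM to 80000 nM.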

Compound 4, half-maximal inhibitory concentration: 69000 nM
Estimate against measurement, compound 4: 2.8-fold (0.44 log units) below, within the range that was stated.
By their numbers in this assay, from the lowest: compounds 1 and 3 (each within the scatter of the next); then compound 4; then compound 2.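

On the saturated ring carbon, adding hydroxy and methoxy to the nitro-bearing ring gives a measurable shift where the earlier nitro swap gave none (a 2.3-fold higher number from compound 3 to compound 4 (0.36 log units; beyond the scatter); a 2.4-fold higher number from compound 1 to compound 4 (0.38 log units; beyond the scatter)). The new ring still reads better than naphthalen-2-yl (a 4.1-fold lower number from compound 2 to compound 4 (0.61 log units; beyond the scatter)), so the position separates single substituted rings from one another as well as from the fused group. Nothing available gives a cause for these steps.

Whether the hydroxy or the methoxy alone accounts for the shift stays open. So does the reading with an amine or a carboxylic acid in place of the nitro group.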